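A few compounds are considered here, and "the series" means these few. Any claim that something is new, unique, unknown or untested is made for them only; others in the source may bear on it.

Of the compounds shown here, two have so far been tested in a functional assay on the whole organism with Mus musculus as the target, in the maximal electroshock model, with a stated time of 4 h; a lower number here means that less compound is needed, a higher number that more compound is needed for the effect. Compound 1, `COc1ccc(C2C=C(n3cc(-c4ccccc4)nc3-c3ccccc3)N=C(S)N2)cc1`, gives 300 mg/kg in this assay. Compound 2, `SC1=NC(n2nc(-c3ccccc3)nc2-c2ccccc2)=CC(c2ccc(-c3ccccc3)cc2)N1`, gives 300 mg/kg in this assay, so compound 2 stands level with compound 1 at the digits shown, and the two values lie within the usual scatter of each other. Compound 3, `Oc1ccc(C2C=C(n3nc(-c4ccccc4)nc3-c3ccccc3)N=C(S)N2)cc1`, has not yet been measured. It differs from compound 2 in one place: hydroxy in place of phenyl on an aromatic carbon. Among the compounds with values here, no pair of measured compounds differs in exactly one place, so no measured step can guide the estimate; the two values so far simply show no movement. With only this to rest on, the expected step is small, none beyond the scatter in either direction: no change at the digits printed from compound 2 to compound 3 (within the scatter). Compound 3 is therefore expected to give about 300 mg/kg in this assay, within a range from 100 mg/kg to 600 mg/kg.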

Compound 3, minimum effective dose: 300 mg/kg
Beside the measured number, compound 3's estimate shows no gap at the digits printed; the range from low to high includes it.
By their numbers in this assay, from the lowest: compounds 1, 2 and 3 (each within the scatter of the next).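

In this assay, replacing the 4-phenylphenyl group with 4-hydroxyphenyl gives no change at the digits printed from compound 2 to compound 3 (within the scatter). Within the data shown here, this is the first step that can be read from a single change, and it shows that at this place on the aromatic ring, a whole six-membered carbon ring can give way to a single hydroxy, which brings a hydrogen-bond donor and acceptor, with no visible effect on the dose needed. Nothing available accounts for this lack of movement.

Going by these compounds, whether an amine or a carboxylic acid at the same place would shift the dose remains open. So does the question of whether any change to this group can move the read-out at all, as this one step shows only a single exchange.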